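The compounds below may be only part of what the source reports. "The series", "measured", "known", "first", "only" and "open" are said of these compounds alone.

Two compounds built on a shared core have been examined so far. Compound 1 `CCCc1nnc(SCC(=O)c2ccc(C)cc2)n1N1C(=O)c2ccccc2C1=O` carries a propyl group on the core. In a functional assay on PC-3M cells (Homo sapiens) for cytotoxicity, read by MTT assay, with a stated time of 48 h (on this read-out lower numbers stand for stronger inhibition and higher numbers for weaker inhibition), compound 1 reaches only a limit, > 200000 nM. Going by the values given here, compound 2 `COc1cc(-c2nnc(SCC(=O)c3ccc(C)cc3)n2N2C(=O)c3ccccc3C2=O)cc(OC)c1OC` instead carries a 3,4,5-trimethoxyphenyl group, and in this assay compound 2 gives 11700 nM, the only actual number among the two values; the step of an at least 17-fold lower number from compound 1 to compound 2 (1.23 log units; beyond the scatter) is the sole measured step. Compound 3 `COc1cc(-c2nnc(SCC(=O)c3ccc(F)c(F)c3)n2N2C(=O)c3ccccc3C2=O)cc(OC)c1OC` now differs from compound 2 in a different place: 3,4-difluorophenyl in place of 4-methylphenyl on a carbonyl carbon. Among the compounds with values here, no measured step touches this part of the molecule, since the only one known concerns the group on the aromatic carbon of the core, so it gives no guidance here and no change beyond the scatter is expected in this assay. The step from compound 2 to compound 3 is expected to be a 1.0-fold higher number from compound 2 to compound 3 (0.01 log units; within the scatter). Compound 3 is therefore estimated at 12000 nM, within a range from 4000 nM to 40000 nM.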

Compound 3, half-maximal inhibitory concentration: 163000 nM
The estimate for compound 3 lay 14-fold (1.13 log units) below the measured number; the whole stated range lies below it.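

Going by these compounds alone, the group on the carbonyl carbon, which no earlier step had touched, turns out to matter in this assay: 3,4-difluorophenyl in place of 4-methylphenyl gives a 14-fold higher number from compound 2 to compound 3 (1.14 log units; beyond the scatter). The 3,4,5-trimethoxyphenyl group is present in both compounds, so it does not settle the number alone, and the group on the carbonyl carbon counts as well. Compound 1 remains the only compound with a limit rather than a number: the limit of > 200000 nM in this assay, at which 1 of the 3 values shown sits.

This one change removes the methyl group and brings in two fluorine atoms together, and the compounds shown do not separate the two; a plain phenyl or a 4-fluorophenyl group on the carbonyl carbon would. Going by these compounds, how a 4-methoxyphenyl or 4-aminophenyl group would fare at this position also remains open.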